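The source may report more compounds than this note shows. Statements on the series, on what has been measured and on what is new or still open speak of the compounds shown alone.

Measured compounds:
compound 1, `CCC(=O)NCC1CCc2c(OC)cccc2N1C`: 112%
compound 2, `CCC(=O)NCCC1CCc2ccccc2N1Cc1ccccc1`: "not determined" (no result reported)

In a functional assay on CHO cells with melatonin receptor type 1A (Homo sapiens) as the target, read by GTPgammaS binding, with a stated time of 1 h (a higher number here means a larger maximal response, a lower number a smaller maximal response), compound 1 gives 112%, a maximal response somewhat above the reference. For the measured compounds named here, compound 1 carries the only number in this assay; compound 2 has "not determined" (no result reported), so no comparison between the two can be drawn. Going by the values given here, with a single measured value there is no step between measured compounds to lean on.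

Compound 3, `CCNC(=O)NCC1CCc2c(OC)cccc2N1C`, differs from compound 1 in one place: ethylamino in place of ethyl on a carbonyl carbon. The propanoylamino group of compound 1 thus becomes a (ethylcarbamoyl)amino group in compound 3. Nothing in the data shows how this change acts in this assay, so any expectation rests on the value of compound 1 alone. A small step, expected to be within the scatter or at most a slight fall in maximal response, is what a number 12 percentage points lower from compound 1 to compound 3 (beyond the scatter) expresses. For compound 3 the estimated value in this assay is 100%, expected to fall between 80% and 120%.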

Compound 3, largest response reached (Emax), in percent of the reference or control that the assay uses: 92%
Beside the measured number, compound 3's estimate is 8 percentage points above it; the range from low to high includes it.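

In this assay, for the compounds shown here, ethylamino in place of ethyl on a carbonyl carbon gives a number 20 percentage points lower from compound 1 to compound 3 (beyond the scatter), the first measured step at this place. It shows that the maximal response is sensitive to what sits on this carbonyl carbon, even though the change from propanoylamino to (ethylcarbamoyl)amino leaves the rest of the core of compound 1 untouched and brings in a hydrogen-bond donor that ethyl lacks. No measurement shown bears on why the response falls, so the step stands without an explanation. The compounds shown leave open whether the step belongs to the entering nitrogen or to the whole ethylamino group, since only this one pair can be compared. A methylamino group, a propylamino chain or a methoxy group on the same carbonyl carbon could separate these readings, and compound 2 adds nothing without a number.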